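Notes on one more fluoro in the series

The compounds below may be only part of what the source reports. "The series", "measured", "known", "first", "only" and "open" are said of these compounds alone.

Compound 1 `Cc1ccc(C2CC(c3ccccc3)=NN2C(=O)c2cc3ccccc3o2)cc1`: 16.6 ug/mL
Compound 2 `O=C(c1cc2ccccc2o1)N1N=C(c2ccccc2)CC1c1ccc(F)cc1`: 9.94 ug/mL

Both values come from a functional assay on A2780 cells (Homo sapiens) for antiproliferative activity, read by MTT assay, with a stated time of 72 h; on this read-out lower numbers stand for stronger inhibition and higher numbers for weaker inhibition. Going by the values given here, compound 2 stands within the scatter of compound 1, the only other measured compound, and the single measured step is a 1.7-fold lower number from compound 1 to compound 2 (0.22 log units; within the scatter). Compound 3 `O=C(c1cc2ccccc2o1)N1N=C(c2ccc(F)cc2)CC1c1ccc(F)cc1` differs from compound 2 by one change: fluoro in place of hydrogen on an aromatic carbon. Among the compounds with values here, only that measured step bears on this change, and it replaces methyl, not hydrogen. No shift beyond the scatter is therefore expected in this assay. The expected step is a 1.1-fold lower number from compound 2 to compound 3 (0.04 log units; within the scatter). Compound 3 is estimated at 9 ug/mL, with an expected range of 4.5 ug/mL to 19 ug/mL.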

Compound 3, half-maximal inhibitory concentration: > 50 ug/mL
Compound 3 was reported as a limit; the forecaster's own chance of this, stated with the estimate: 3%; middle value at least 5.5-fold (0.74 log units) from the limit.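

In this assay, fluoro in place of hydrogen at this position, phenyl to 4-fluorophenyl, gives an at least 5.0-fold higher number from compound 2 to compound 3 (0.70 log units; beyond the scatter), which is beyond the scatter. Going by these compounds alone, the only earlier step, a 1.7-fold lower number from compound 1 to compound 2 (0.22 log units; within the scatter), stayed within the scatter and involved a different place and a replacement of methyl, so it gave no sign that this carbon could respond to a single fluoro. Compound 3 is reported as a limit: the limit of > 50 ug/mL in this assay, at which 1 of the 3 values shown sits.

Going by these compounds, the true size of the step stays open. So does whether an amine or a methoxy group on this carbon would shift the number in the same direction.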